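Swapping the anilide ring on a fluorobenzyloxy coumarin amide

The compounds below may be only part of what the source reports. "The series", "measured", "known", "first", "only" and "open" are said of these compounds alone.

Measured compounds:
compound 1, `COc1ccc(NC(=O)c2cc3ccccc3oc2=O)cc1OC`, 9450 nM
compound 2, `Cc1cccc(Cl)c1NC(=O)c1cc2ccc(OCc3ccc(F)cc3)cc2oc1=O`, 59600 nM

Both were tested in an in vitro assay on BTI-TN-5B1-4 cells for inhibition of Amine oxidase [flavin-containing] A (Homo sapiens), read by fluorescence; a lower number here means a stronger inhibitor, a higher number a weaker inhibitor. Compound 1 gives 9450 nM, and compound 2 gives 59600 nM. Among the compounds with values here, compound 2 thus stands at the highest of the two numbers; its gap to compound 1, the only neighbour, lies beyond the scatter. Within the data shown here, the two differ in more than one place, so no single step between them can be read.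

Compound 3, `COc1ccc(NC(=O)c2cc3ccc(OCc4ccc(F)cc4)cc3oc2=O)cc1OC`, has not yet been measured. It differs from compound 2 in one place: 3,4-dimethoxyphenyl in place of 2-chloro-6-methylphenyl on an amide-type nitrogen. This puts onto the core of compound 2 the same amide-type substituent that compound 1 carries, while the fluorobenzyloxy group of compound 2 is kept.

Because compound 1 with the same dimethoxyphenyl gives 9450 nM, the number for compound 3 is expected to fall below that of compound 2, with a step of about a 4.0-fold lower number from compound 2 to compound 3 (0.60 log units; beyond the scatter) in this assay, though the remaining difference to compound 1 leaves the size open. Compound 3 is estimated at 15000 nM, within a range from 3000 nM to 60000 nM.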

Compound 3, half-maximal inhibitory concentration: 49200 nM
For compound 3 the middle estimate is 3.3-fold (0.52 log units) below the measured one; measured number inside the range.
By their numbers in this assay, from the lowest: compound 1; then compounds 3 and 2 (each within the scatter of the next).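

In this assay, 3,4-dimethoxyphenyl in place of 2-chloro-6-methylphenyl on the amide-type nitrogen gives a 1.2-fold lower number from compound 2 to compound 3 (0.08 log units; within the scatter), so with the fluorobenzyloxy group in place, these two substituents on the amide-type nitrogen cannot be told apart. Within the data shown here, with 3,4-dimethoxyphenyl held fixed, (4-fluorobenzyl)oxy in place of hydrogen on an aromatic carbon gives a 5.2-fold higher number from compound 1 to compound 3 (0.72 log units; beyond the scatter), the first reading of what that group does. Of the two one-place changes now available, only this second one lies beyond the scatter, and it is a modest step.

As far as these compounds go, whether an amine or a carboxylic acid on the phenyl ring of the amide, or a longer chain in place of the (4-fluorobenzyl)oxy group, would shift the number remains open, as does whether 2-chloro-6-methylphenyl and 3,4-dimethoxyphenyl also match on the core without that group. Nothing shown here bears on why either step has the size it has.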